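A few compounds are considered here, and "the series" means these few. Any claim that something is new, unique, unknown or untested is made for them only; others in the source may bear on it.

In a functional assay on MT4 cells (Homo sapiens) for cytotoxicity (on this read-out higher numbers stand for weaker inhibition and lower numbers for stronger inhibition), a high number means a compound is weak at harming the cells and a low number means it is strong. Compound 1 `N#Cc1c(N)cccc1S(=O)(=O)c1cccc(Cl)c1` gives > 200000 nM, which is a limit of the assay and not a number. For the measured compounds named here, compound 2 `Cc1cc(Br)cc(S(=O)(=O)c2cccc(N)c2C#N)c1` gives 133000 nM, the only real number measured so far. Going by the values given here, it therefore stands alone as a reference point, and no measured pair that differs in one place shows how a single swap behaves in this assay.

Compound 3 `Cc1cc(Cl)cc(S(=O)(=O)c2cccc(N)c2C#N)c1` differs from compound 2 at one spot, with chloro in place of bromo on an aromatic carbon, meta to a large group and meta to a methyl group: chloro in place of bromo on an aromatic carbon. With nothing measured for such a swap, the best guide is compound 2 at 133000 nM, so no change beyond the usual scatter of repeat measurements is expected. The expected step is a 1.1-fold higher number from compound 2 to compound 3 (0.02 log units; within the scatter). Compound 3 is estimated at 140000 nM, with an expected range of 70000 nM to 200000 nM, though the assay could also report only a limit.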

Compound 3, half-maximal inhibitory concentration: > 200000 nM
Compound 3 ended at the assay's limit (the forecaster's own chance of this, stated with the estimate: 35%); at least 1.4-fold (0.15 log units) between middle value and limit.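

In this assay, for the compounds shown here, chloro in place of bromo on this aromatic carbon, meta to a large group and meta to a methyl group, gives the first step that can be read at all: an at least 1.5-fold higher number from compound 2 to compound 3 (0.17 log units; that floor lies within the scatter). Only a lower bound is known for this step and it lies within the scatter, so the change from bromo to chloro is not shown to matter, yet the true size of the step could be larger. The step from compound 1 to compound 3, methyl in place of hydrogen, cannot be read, and the picture at this position stays thin because so many of the values stop at the same point: the limit of > 200000 nM in this assay, at which 2 of the 3 values shown sit.

From the compounds shown here alone, what the shared core would do with a fluoro, a methoxy group or an amine on this same aromatic carbon remains open, as only bromo and chloro appear there. Also open, going by these compounds, is whether any group at this position can bring the number clearly down from that limit, which would give a second real number to set beside compound 2.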